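Z to E switch in the second pair

This account rests on a few compounds, and the source may have more. Where it says the series, first, only, none or still open, it means among the compounds named here.

Measured in a functional assay on HT-29 cells (Homo sapiens) for cytotoxicity; on this read-out lower numbers stand for stronger inhibition and higher numbers for weaker inhibition:
- compound 1 `COc1cc(/C=C\c2ccc3ccccc3n2)cc(OC)c1OC`: 316 nM
- compound 2 `COc1cc(/C=C/c2ccc3ccccc3n2)cc(OC)c1OC`: 398 nM
- compound 3 `COc1cc(/C=C\c2cnc3ccccc3c2)cc(OC)c1OC`: 398 nM

Compound 3 gives 398 nM, the same number as compound 2 at 398 nM, and all three values lie within the scatter of one another. The next compound is compound 4 `COc1cc(/C=C/c2cnc3ccccc3c2)cc(OC)c1OC`, and the change is the two compounds have the same atoms and bonds and differ only in configuration as drawn: 1 of 1 stereo elements differ; a double bond is drawn Z in compound 3 and E in compound 4. Within the data shown here, the only measured step of this kind, a 1.3-fold higher number from compound 1 to compound 2 (0.10 log units; within the scatter), leads to the expectation of no change beyond the scatter in this assay, in either direction. This rests on a single pair, so the range is kept wide. The expected step is a 1.3-fold higher number from compound 3 to compound 4 (0.10 log units; within the scatter). The estimate for compound 4 is 500 nM, with an expected range from 200 nM to 1500 nM.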

Compound 4, half-maximal inhibitory concentration: > 3160 nM
Compound 4: only a limit was reported (the forecaster's own chance of this, stated with the estimate: 3%); middle value at least 6.3-fold (0.80 log units) from the limit.
By their numbers in this assay, from the lowest: compounds 1, 2 and 3 (each within the scatter of the next). At a limit, above all of these: compound 4.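

The same Z to E change gives an at least 7.9-fold higher number from compound 3 to compound 4 (0.89 log units; beyond the scatter) in this assay, against a 1.3-fold higher number from compound 1 to compound 2 (0.10 log units; within the scatter) in the other pair, so its outcome is not the same across the two pairs. Compound 4 gives > 3160 nM, which is a limit of the assay and not a number. The step in this pair is tied to the double bond alone: the fact that compounds 3 and 4 differ only in the configuration as drawn

On these data alone, the true size of that step stays open. Also open, as far as these compounds go, is whether the Z to E change would give a step of this kind with an amine or a carboxylic acid on the shared core.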